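Ester and Amide Pairs at the Urotensin-2 Receptor

A few compounds are considered here, and "the series" means these few. Any claim that something is new, unique, unknown or untested is made for them only; others in the source may bear on it.

Compound 1 `Cc1c(Cl)cccc1C(=O)OC(CCN(C)C)c1ccc(Cl)cc1` is the starting point; in an assay on NIH3T3 cells with Urotensin-2 receptor (Homo sapiens) as the target (on this read-out lower numbers stand for an effect already at smaller amounts and higher numbers for an effect only at larger amounts of compound), compound 1 gives 1120 nM. Compound 2 `Cc1ccc(C)c(C(=O)OC(CCN(C)C)c2ccc(Cl)cc2)c1` differs from it in a single place: 2,5-dimethylphenyl in place of 3-chloro-2-methylphenyl on a carbonyl carbon. Across that change the measured step was a 1.7-fold higher number from compound 1 to compound 2 (0.22 log units; within the scatter). Compound 3 `Cc1c(Cl)cccc1C(=O)NC(CCN(C)C)c1ccc(Cl)cc1` carries the same 3-chloro-2-methylphenyl group as compound 1 on a different core; the difference between the two cores is not broken down here. In this assay compound 3 gives 1740 nM, while compound 2 gives 1860 nM. Compound 4 `Cc1ccc(C)c(C(=O)NC(CCN(C)C)c2ccc(Cl)cc2)c1` is not yet measured. It stands to compound 3 as compound 2 stands to compound 1: 2,5-dimethylphenyl in place of 3-chloro-2-methylphenyl on a carbonyl carbon. The surroundings are not identical, though: in the first pair the carbonyl carbon's other neighbour is oxygen next to a carbonyl group, in the second it is an amide-type nitrogen, so this is the same kind of change rather than the same change. For the measured compounds named here, the step expected in this assay is a 1.7-fold higher number from compound 3 to compound 4 (0.22 log units; within the scatter), an estimate resting on the single earlier pair because of a 1.7-fold higher number from compound 1 to compound 2 (0.22 log units; within the scatter). Compound 4 is therefore expected to give about 2900 nM, plausibly between 1400 nM and 6000 nM.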

Compound 4, half-maximal effective concentration: 2880 nM
Compound 4: the middle estimate sits 1.0-fold (0.00 log units) above what was measured; the range from low to high includes it.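

On the core with the amide-type nitrogen, putting 2,5-dimethylphenyl in place of 3-chloro-2-methylphenyl gave a 1.7-fold higher number from compound 3 to compound 4 (0.22 log units; within the scatter) in this assay. Set beside the same change on the core of compound 1, the two steps match: the same change on two cores in this assay, a 1.7-fold higher number (0.22 log units; within the scatter) from compound 1 to compound 2 and a 1.7-fold higher number (0.22 log units; within the scatter) from compound 3 to compound 4, 1.0-fold (0.00 log units) apart, within the scatter of two such steps. This shows that, in these two pairs, the change carried from one core to the other with no difference that can be told from the scatter, but each step on its own also lies within the scatter, so it does not show that the change really shifts the number, and two pairs cannot speak for other cores or other groups.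

The compounds shown leave open whether a more different group on the aromatic ring, such as an amine or a carboxylic acid, would move the number beyond the scatter, and whether such a step would also carry from one core to the other. For the compounds shown here, they also leave open what a longer chain in place of the one bearing the dimethylamino group would do on either core.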